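The source may report more compounds than this note shows. Statements on the series, on what has been measured and on what is new or still open speak of the compounds shown alone.

Measured compounds:
Compound 1, `ClCc1ccc(Cn2cnc3c(Cl)ncnc32)cc1`: 410 nM
Compound 2, `ClCc1cccc(Cn2cnc3ncnc(Cl)c32)c1`: 1580 nM

Both were tested in a functional assay on MCF7 cells (Homo sapiens) for cytotoxicity, read by sulforhodamine B assay, with a stated time of 48 h; a higher number here means a weaker inhibitor of growth, a lower number a stronger inhibitor of growth. Compound 1 gives 410 nM and stands lowest of the two numbers. Compound 2 gives 1580 nM, a higher number, and the gap between the two lies beyond the usual scatter of this assay.

Compound 3, `ClCc1ccc(Cn2cnc3c(Cl)nc(Cl)nc32)cc1`, has not yet been measured. It differs from compound 1 in one place: chloro in place of hydrogen on an aromatic carbon. Within the data shown here, no measured pair of compounds shows this particular change, so its size and direction are not known from the data at hand.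

The step of a 1.2-fold lower number from compound 1 to compound 3 (0.07 log units; within the scatter) is expected to be small, within or only just beyond the scatter, in either direction. Compound 3 is therefore estimated at 350 nM, with a range from 120 nM to 1000 nM.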

Compound 3, concentration for 50% growth inhibition: 1740 nM
Estimate against measurement, compound 3: 5.0-fold (0.70 log units) below, outside the stated range (above it).
By their numbers in this assay, from the lowest: compound 1; then compounds 2 and 3 (each within the scatter of the next).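

In this assay the ring carbon between two ring nitrogen atoms proves sensitive to substitution: chloro in place of hydrogen there gives a 4.2-fold higher number from compound 1 to compound 3 (0.63 log units; beyond the scatter) and so weakens growth inhibition. Compounds 1 and 2 both carry hydrogen on this carbon, so they could not show whether a change here matters or in which direction it moves the number. Nothing in the data accounts for why this single added atom has such an effect.

As far as these compounds go, it remains open whether another group on this carbon, such as an amine, a methoxy group or a short alkyl chain, would also raise the number, leave it unchanged or lower it. From the compounds shown here alone, it is also open whether chloro here would produce a similar step if the chloromethyl group on the benzyl ring were replaced.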